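Swapping chloro for methyl on the arylsulfonyl ring

The source may hold more compounds than are shown below. What is called first, only, known or untested is meant among the compounds shown, and "the series" means these compounds.

Measured compounds:
- compound 1 `Cc1ccc(S(=O)(=O)N2CCN(C[C@H](C)Nc3ncnc4c(C)csc34)CC2)cc1`: 170 nM
- compound 2 `CCCCS(=O)(=O)N1CCN(C[C@H](C)Nc2ncnc3c(C)csc23)CC1`: 6610 nM
- compound 3 `Cc1csc2c(N[C@@H](C)CN3CCN(S(=O)(=O)c4cccc(Cl)c4)CC3)ncnc12`: 35 nM

All three were tested in a functional assay on RH7777 cells for antagonist activity at lysophosphatidic acid receptor 2 (Homo sapiens), read by calcium flux; a lower number here means a stronger inhibitor, a higher number a weaker inhibitor. Compound 3 gives the lowest number of the three: the step of a 4.9-fold lower number from compound 1 to compound 3 (0.69 log units; beyond the scatter) is modest, and a 190-fold lower number from compound 2 to compound 3 (2.28 log units; beyond the scatter) is large. Among the measured compounds shown here, the one non-aromatic analogue, compound 2, stands far behind, as a 39-fold higher number from compound 1 to compound 2 (1.59 log units; beyond the scatter) shows.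

Compound 4 `Cc1cccc(S(=O)(=O)N2CCN(C[C@H](C)Nc3ncnc4c(C)csc34)CC2)c1` keeps everything of compound 3 except for one change: methyl in place of chloro on an aromatic carbon, on an aromatic carbon of the six-membered aromatic ring of carbon only, meta to a large group. For the measured compounds named here, no measured step tests a chloro-to-methyl exchange at this position. What the data do show is that an aryl group on the sulfonyl sulfur is strongly preferred over butyl, and that the 3-chlorophenyl of compound 3 outperforms the 4-methylphenyl of compound 1 by a modest margin. Since the aromatic ring is retained, the expected step of a 2.0-fold higher number from compound 3 to compound 4 (0.30 log units; within the scatter) is small, most likely a somewhat higher number. Compound 4 is therefore estimated at 70 nM, within a range of 25 nM to 200 nM.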

Compound 4, half-maximal inhibitory concentration: 310 nM
For compound 4 the middle estimate is 4.4-fold (0.65 log units) below the measured one; the measured number lies above the stated range.
By their numbers in this assay, from the lowest: compound 3; then compounds 1 and 4 (each within the scatter of the next); then compound 2.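

In this assay, exchanging chloro for methyl on this aromatic carbon is not a neutral swap: an 8.9-fold higher number from compound 3 to compound 4 (0.95 log units; beyond the scatter) shows that compound 3's lead depends on the chloro and not merely on having an aryl group on the sulfonyl sulfur. The methyl group's location on the ring makes no difference that can be read, since a 1.8-fold higher number from compound 1 to compound 4 (0.26 log units; within the scatter) stays within the scatter. The preference for aryl over butyl nevertheless survives without the chloro, as a 21-fold lower number from compound 2 to compound 4 (1.33 log units; beyond the scatter) shows. The data offer no explanation for the gap between chloro and methyl. From the compounds shown here alone, whether bromo, methoxy or trifluoromethyl at this place would behave like chloro or like methyl remains open, as does whether any of them would go beyond compound 3.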